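The source may report more compounds than this note shows. Statements on the series, on what has been measured and on what is new or still open speak of the compounds shown alone.

Working notes on a small series of acylhydrazide compounds.

Compound 1 is `O=C(NNC(=O)c1cc([N+](=O)[O-])c[nH]1)Nc1ccc(Br)cc1`. Compound 2 is `Cc1ccccc1NC(=S)NNC(=O)c1cc([N+](=O)[O-])c[nH]1`. Compound 3 is `Cn1cc([N+](=O)[O-])cc1C(=O)NNC(=O)Nc1ccc(Br)cc1`. Compound 4, not yet measured, is `Cc1ccccc1NC(=S)NNC(=O)c1cc([N+](=O)[O-])cn1C`.

In an ADME assay on Vero cells (Chlorocebus sabaeus) for cytotoxicity, read by MTT assay, with a stated time of 72 h (on this read-out higher numbers stand for weaker inhibition and lower numbers for stronger inhibition), compound 1 gives 378000 nM. In this assay compound 2 gives 462000 nM, and compound 3 gives 602000 nM. All three numbers sit close together, and no one of them can be set apart from the others.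

One single-point change is present among the measured compounds: methyl in place of hydrogen on an aromatic nitrogen. It carries a 1.6-fold higher number from compound 1 to compound 3 (0.20 log units; within the scatter).

The cores of compound 1 and compound 2 differ in more than one place, and that difference between the two cores is not broken down here.

Compound 4 arises from compound 2 by the same change: methyl in place of hydrogen on an aromatic nitrogen. The surroundings of the place are described in the same words as for the step from compound 1 to compound 3, so the change counts as the same, made on a different core.

Among the measured compounds shown here, for compound 4 in this assay the expected step is a 1.4-fold higher number from compound 2 to compound 4 (0.15 log units; within the scatter), set beside a 1.6-fold higher number from compound 1 to compound 3 (0.20 log units; within the scatter); this rests on the one measured example of this change, with compound 1 and compound 3 as the only pair on which the expectation can lean. The estimate for compound 4 in this assay is 650000 nM, with a range from 350000 nM to 1200000 nM.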

Compound 4, half-maximal inhibitory concentration: 471000 nM
The estimate for compound 4 lay 1.4-fold (0.14 log units) above the measured number, within the range that was stated.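

In this assay, methyl in place of hydrogen on an aromatic nitrogen gives a 1.0-fold higher number from compound 2 to compound 4 (0.01 log units; within the scatter), a step that cannot be told from the scatter on the core of compound 2. Set beside the earlier example, the two steps cannot be told apart, so the change carries across these two cores without a readable difference: the same change on two cores in this assay, a 1.6-fold higher number (0.20 log units; within the scatter) from compound 1 to compound 3 and a 1.0-fold higher number (0.01 log units; within the scatter) from compound 2 to compound 4, 1.6-fold (0.19 log units) apart, within the scatter of two such steps. Among the compounds shown here, this agreement rests on only two pairs, each with a step inside the scatter, so it shows neither that the change has a real size or direction nor that the same would hold on any core other than those of compound 1 and compound 2.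

Still open, going by these compounds, is whether an ethyl group or a longer chain on the same aromatic nitrogen, or a chain ending in an amine or a carboxylic acid, would take the number in this assay beyond the scatter. Also open, on these data alone, is whether the methyl step would stay as small with a nitrile in place of the nitro group on the same ring.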